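Swapping the Amine Substituent: From Phenyl to Pyrazole

This account rests on a few compounds, and the source may have more. Where it says the series, first, only, none or still open, it means among the compounds named here.

Of the compounds shown here, three sharing one core have been tested in a functional assay on A549 cells (Homo sapiens) for antiproliferative activity, read by sulforhodamine B assay, with a stated time of 72 h; on this read-out higher numbers stand for weaker inhibition and lower numbers for stronger inhibition. Compound 1 `COc1ncc(-c2ccc3ncnc(Nc4cnn(CC(=O)O)c4)c3c2)cc1NS(=O)(=O)c1ccc(F)cc1F` gives 5200 nM. Compound 2 `CCCCS(=O)(=O)Nc1cc(-c2ccc3ncnc(Nc4ccc(OCCO)nc4)c3c2)cnc1OC` gives 13300 nM. Compound 3 `COc1ncc(-c2ccc3ncnc(Nc4ccc(OCCO)c(Cl)c4)c3c2)cc1NS(=O)(=O)c1ccc(F)cc1F` gives 5980 nM, which is the second highest of the three numbers; compound 1 is nearest, with a number that lies within the scatter of it, and compound 2 is furthest, with a higher number that lies beyond the scatter. Going by the values given here, no single-point step links compound 2 and compound 3, so their two values are all that can be said of them.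

Compound 4 `COc1ncc(-c2ccc3ncnc(Nc4cnn(CCCO)c4)c3c2)cc1NS(=O)(=O)c1ccc(F)cc1F` has not yet been measured. It differs from compound 3 in one place: 1-(3-hydroxypropyl)-1H-pyrazol-4-yl in place of 3-chloro-4-(2-hydroxyethoxy)phenyl on a nitrogen on an aromatic ring

Among the compounds with values here, the only measured step that bears on this is a 1.2-fold higher number from compound 1 to compound 3 (0.06 log units; within the scatter). Read backwards, it shows that replacing the phenyl group on that nitrogen with a pyrazole carrying a short substituent changed the number only within the scatter. Compound 4 carries a pyrazole with a 1-(3-hydroxypropyl) group instead, so the step of a 1.2-fold lower number from compound 3 to compound 4 (0.10 log units; within the scatter) is expected to be small, with no change beyond the scatter. Compound 4 is therefore estimated at 4800 nM, within a range from 2000 nM to 11500 nM.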

Compound 4, half-maximal inhibitory concentration: 4830 nM
Estimate against measurement, compound 4: 1.0-fold (0.00 log units) below; the measured number falls inside the stated range.
By their numbers in this assay, from the lowest: compounds 4, 1 and 3 (each within the scatter of the next); then compound 2.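

In this assay, 1-(3-hydroxypropyl)-1H-pyrazol-4-yl in place of 3-chloro-4-(2-hydroxyethoxy)phenyl on the amine nitrogen gives a 1.2-fold lower number from compound 3 to compound 4 (0.09 log units; within the scatter), so a second pyrazole on this nitrogen also reads the same as the chlorine-bearing phenyl group within the scatter. The end of the chain on the pyrazole can now be compared as well: 2-hydroxyethyl in place of carboxy on a saturated chain carbon bound to an aromatic nitrogen gives a 1.1-fold lower number from compound 1 to compound 4 (0.03 log units; within the scatter), and this too leaves the two compounds indistinguishable, a comparison that was not possible with only one pyrazole in hand. No measurement shown here offers a reason for this lack of difference.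

Still open, on these data alone, is whether any group at this position can move the number beyond the scatter, and a pyrazole chain ending in an amine, or a much longer carbon chain, on the same core would test that. Compound 2 differs from these compounds in more than one place, so the effect of its pyridine-like group on this nitrogen cannot be separated from that of its other differences.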